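Benzyloxy to acetoxy on the shared core

The source may report more compounds than this note shows. Statements on the series, on what has been measured and on what is new or still open speak of the compounds shown alone.

Measured in a functional assay on BE cells (Homo sapiens), read by MTT assay, with a stated time of 24 h; a lower number here means a stronger inhibitor, a higher number a weaker inhibitor:
- compound 1 `COc1ccc(-c2cnc3cc(C)c(C)cc3n2)cc1O`: > 50000 nM (a limit)
- compound 2 `Cc1cc2ncc(-c3ccc(OCc4ccccc4)c(O)c3)nc2cc1C`: 41000 nM

Within the data shown here, compound 2 gives 41000 nM, the only actual number so far. Compound 1 reads > 50000 nM, which is a limit.

Compound 3 `CC(=O)Oc1ccc(-c2cnc3cc(C)c(C)cc3n2)cc1O` differs from compound 2 in one place: acetyl in place of benzyl on an oxygen on an aromatic ring. In words, this is acetyl in place of benzyl on an oxygen on an aromatic ring.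

Among the measured compounds shown here, one measured step bears on this change, as it also alters the group on that oxygen: an at least 1.2-fold lower number from compound 1 to compound 2 (0.08 log units; that floor lies within the scatter). Its floor lies within the scatter, so no clear gain in this assay is expected from either group, and a reading at the limit remains likely.

An estimated 1.2-fold higher number from compound 2 to compound 3 (0.09 log units; within the scatter) is expected, not beyond the scatter.

Compound 3 is expected at 50000 nM, with an estimated range of 25000 nM to 100000 nM.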

Compound 3, half-maximal inhibitory concentration: > 50000 nM
Compound 3 was reported as a limit; the forecaster's own chance of this, stated with the estimate: 55%; the middle value lies on the limit itself.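

In this assay, acetyl on this oxygen gives no reading inside the measurable range, and compound 3 reads > 50000 nM, a limit. Set against benzyl, the change gives an at least 1.2-fold higher number from compound 2 to compound 3 (0.08 log units; that floor lies within the scatter), so neither the smaller acetyl, with its carbonyl acceptor, nor benzyl separates clearly from the other at this position, and the step from compound 1 to compound 3 cannot be read, as both values are limits. The series therefore now has methyl and acetyl on this oxygen at the limit and only benzyl with an actual number, and most of it sits at one reading: the limit of > 50000 nM in this assay, at which 2 of the 3 values shown sit.

On these data alone, whether any group on this oxygen can bring the number clearly down remains open. An amine or a carboxylic acid at the end of a longer chain there would test this, as would a substituted benzyl.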